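The source may hold more compounds than are shown below. What is called first, only, known or untested is meant among the compounds shown, and "the series" means these compounds.

Working notes on the series. In an ADME assay (Rattus norvegicus, strain Han-wistar) for metabolic stability, at a dose of 1.5 umol/kg by the intravenous route (on this read-out lower numbers stand for a shorter-lived compound and higher numbers for a longer-lived compound), compound 3 (`CC(C)n1cc(-c2ccnc3[nH]c(C4CCN(CC(=O)N5CCCCC5)CC4)cc23)ccc1=O`) gives 1.7 h. Compound 1 (`CC(C)n1nc(-c2ccnc3[nH]c(C4CCN(CC(=O)N(C)C)CC4)cc23)ccc1=O`) gives 1 h and compound 2 (`CC(C)n1cc(-c2ccnc3[nH]c(C4CCN(CC(=O)N(C)C)CC4)cc23)cnc1=O`) gives 1 h. All three numbers lie within the scatter of one another, so compound 3 cannot be ranked against the other two.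

Compound 4 (`CC(C)n1cc(-c2ccnc3[nH]c(C4CCN(CC(=O)N(C)C)CC4)cc23)ccc1=O`) differs from compound 3 by dimethylamino in place of piperidin-1-yl on a carbonyl carbon.

Among the compounds with values here, the only measured step is no change at the digits printed from compound 1 to compound 2 (within the scatter). It exchanges one six-membered aromatic ring with 2 hetero atoms for another and leaves the dimethylamino on the carbonyl carbon untouched, so it bears on the present change only indirectly. Within the data shown here, no measured step isolates the exchange of piperidin-1-yl for dimethylamino. The closest guide is that compound 1, at 1 h, and compound 2, at 1 h, both carry dimethylamino on that carbonyl carbon and still sit within the scatter of compound 3.

In this assay, the expected change is therefore a 1.4-fold lower number from compound 3 to compound 4 (0.15 log units; within the scatter), with no shift beyond the scatter anticipated. For compound 4 the estimate is 1.2 h, with an expected range from 0.7 h to 2.2 h.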

Compound 4, half-life in the Rattus norvegicus assay: 1.7 h
Beside the measured number, compound 4's estimate is 1.4-fold (0.15 log units) below it; the range from low to high includes it.
By their numbers in the Rattus norvegicus assay, from the lowest: compounds 1, 2, 3 and 4 (each within the scatter of the next).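

Within the data shown here, on the carbonyl carbon, the Rattus norvegicus assay gives no change at the digits printed from compound 3 to compound 4 (within the scatter), so in the one pair that isolates this exchange, dimethylamino and piperidin-1-yl cannot be told apart on this read-out. With dimethylamino held in place on that carbon, the Rattus norvegicus assay gives a 1.7-fold higher number from compound 2 to compound 4 (0.23 log units; within the scatter) and a 1.7-fold higher number from compound 1 to compound 4 (0.23 log units; within the scatter), so the exchange of the group on the aromatic carbon also stays inside the scatter, and none of these pairs separates on this read-out. In a physicochemical assay for solubility, in phosphate buffer, at pH 7.4 (a higher number here means a more soluble compound, a lower number a less soluble compound), the exchange on the carbonyl carbon gives a 1.4-fold higher number from compound 3 to compound 4 (0.14 log units; within the scatter), with compound 3 at 79000 nM and compound 4 at 110000 nM, so the ring of piperidin-1-yl can give way to the open dimethylamino with no shift beyond the scatter on either read-out.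

Going by these compounds, it remains open whether a group of another kind on this carbonyl carbon, such as morpholin-4-yl or a 4-methylpiperazin-1-yl ring, would move either read-out beyond the scatter. No evidence at hand offers a reason for any of these readings.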